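A few compounds are considered here, and "the series" means these few. Any claim that something is new, unique, unknown or untested is made for them only; others in the source may bear on it.

In a functional assay on A549 cells (Homo sapiens) for antiproliferative activity, read by sulforhodamine B assay, with a stated time of 48 h (a lower number here means a stronger inhibitor of growth, a higher number a weaker inhibitor of growth), compound 1 `CC(C)CCc1c(OCCCCCCC(=O)NO)ccc2c1OC(=O)CC2` reads > 30000 nM. That figure is a limit of the assay and not a number, so compound 1 has no exact position on the scale. Two related compounds do give numbers. Compound 2 `CC(C)CCc1c(OCCCCCCCC(=O)NO)ccc(CCC(=O)NO)c1O` gives 2670 nM and compound 3 `CC(C)CCc1c(OCCCCC(=O)NO)ccc2ccc(=O)oc12` gives 2760 nM, two values within the usual scatter of each other.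

Compound 4 `CC(C)CCc1c(OCCCCCCCC(=O)NO)ccc2c1OC(=O)CC2` keeps the core of compound 1 and alters only the chain: (hydroxycarbamoyl)methyl in place of hydroxycarbamoyl on a saturated chain carbon, six bonds along the chain from an oxygen on an aromatic ring. In words, (hydroxycarbamoyl)methyl stands in place of hydroxycarbamoyl on a saturated chain carbon, six bonds along the chain from an oxygen on an aromatic ring. Among the compounds with values here, no measured pair isolates this change, so any expectation rests on indirect evidence. The chain of compound 4 also occurs on a different core in compound 2, which gives 2670 nM. Stronger growth inhibition is therefore expected in this assay, though the different core leaves the size uncertain. The estimated step is an at least 3.7-fold lower number from compound 1 to compound 4 (0.57 log units; beyond the scatter). For compound 4 the expected value is 8000 nM, with an estimated range of 2500 nM to 28000 nM.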

Compound 4, concentration for 50% growth inhibition: > 30000 nM
Compound 4 ended at the assay's limit (the forecaster's own chance of this, stated with the estimate: 25%); middle value at least 3.7-fold (0.57 log units) from the limit.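

Compound 1 and compound 4 both stand at a limit of the assay and not at a number, so no step can be read between them: the limit of > 30000 nM in this assay, at which 2 of the 4 values shown sit.

The compounds shown leave open whether (hydroxycarbamoyl)methyl in place of hydroxycarbamoyl changes growth inhibition on this shared core at all.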